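A few compounds are considered here, and "the series" means these few. Any claim that something is new, unique, unknown or untested is made for them only; others in the source may bear on it.

Measured so far in an assay on isolated protein for inhibition of protein deacetylase HDAC6 (Homo sapiens), read by fluorescence; a lower number here means a stronger inhibitor, a higher number a weaker inhibitor:
compound 1, `Cn1cc(-c2ccccc2Oc2ccccc2)c2cc(C(=O)NCc3ccc(C(=O)Nc4ccccc4N)cc3)[nH]c2c1=O`, a limit of > 500 nM
compound 2, `Cn1cc(-c2ccccc2Oc2ccccc2)c2cc(C(=O)NCCCCCCC(=O)NO)[nH]c2c1=O`, 4.7 nM
compound 3, `Cn1cc(-c2ccccc2Oc2ccccc2)c2cc(C(=O)NCCCCC(=O)NO)[nH]c2c1=O`, 4 nM

Compound 3 stands within the scatter of compound 2: the step of a 1.2-fold lower number from compound 2 to compound 3 (0.07 log units; within the scatter) amounts to no real difference between the two hydroxycarbamoyl chains. Compound 1 returns only a limit in this assay, so it gives no number to place beside the other two.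

Compound 4, `Cn1cc(-c2ccccc2Oc2ccccc2)c2cc(C(=O)NCc3ccc(C(=O)NO)cc3)[nH]c2c1=O`, is not yet measured. Relative to compound 3 it carries 4-(hydroxycarbamoyl)phenyl in place of 3-(hydroxycarbamoyl)propyl on a saturated chain carbon bound to an amide-type nitrogen; cut one bond further out, the same change reads 4-(hydroxycarbamoyl)butyl to 4-(hydroxycarbamoyl)benzyl. Going by the values given here, the only measured step, a 1.2-fold lower number from compound 2 to compound 3 (0.07 log units; within the scatter), varies chain length with the hydroxycarbamoyl end kept and stayed within the scatter; no measured step exchanges a saturated chain for an aromatic ring with that end kept. Among the compounds with values here, compound 1 differs from compound 4 in the group on the ring, and for that pair no step is computed. Compound 1 offers only a limit.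

The expectation for compound 4 therefore rests on compounds 2 and 3 with a widened margin. A step of a 2.5-fold higher number from compound 3 to compound 4 (0.40 log units; beyond the scatter) is expected, modest and uncertain in direction. Compound 4 is estimated at 10 nM, within 3 nM to 40 nM.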

Compound 4, half-maximal inhibitory concentration: 15.3 nM
Compound 4: middle estimate off by 1.5-fold (0.18 log units), on the low side, and the stated range covers the measured number.
By their numbers in this assay, from the lowest: compounds 3 and 2 (each within the scatter of the next); then compound 4. At a limit, above all of these: compound 1.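

Going by these compounds alone, at the saturated chain carbon bound to an amide-type nitrogen, 4-(hydroxycarbamoyl)phenyl in place of 3-(hydroxycarbamoyl)propyl gives the first change at this position that lies beyond the scatter in this assay, with a 3.8-fold higher number from compound 3 to compound 4 (0.58 log units; beyond the scatter); against the longer chain the picture is the same, with a 3.3-fold higher number from compound 2 to compound 4 (0.51 log units; beyond the scatter). Chain length alone had shown no real difference, with a 1.2-fold lower number from compound 2 to compound 3 (0.07 log units; within the scatter), so these notes now have an aromatic ring as the one exchange at this position that registers, and its size is modest with the hydroxycarbamoyl end kept. Compound 1 stands at a limit and not at a number, so an at least 32-fold lower number from compound 1 to compound 4 (1.51 log units; beyond the scatter) is a bound only, for hydroxy in place of 2-aminophenyl on an amide-type nitrogen with the rest of the structure kept: the limit of > 500 nM in this assay, at which 1 of the 4 values shown sits.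

Still open, going by these compounds, is whether a pyridine ring carrying the hydroxycarbamoyl end, or a shorter chain such as 2-(hydroxycarbamoyl)ethyl, would fall with the saturated chains or with compound 4. Also open, on these data alone, is how a carboxylic acid would compare with the hydroxycarbamoyl end on the 4-substituted benzyl group of compound 4.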